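Removing the nitro group from compound 1: expected outcome

The source may hold more compounds than are shown below. What is called first, only, known or untested is meant among the compounds shown, and "the series" means these compounds.

Of the compounds shown here, three have a number so far in a functional assay on K562 cells (Homo sapiens) for inhibition, read by trypan blue exclusion, with a stated time of 72 h; a lower number here means a stronger inhibitor, a higher number a weaker inhibitor. Compound 1 `Cn1c(=O)c(S(=O)(=O)c2ccc(F)cc2[N+](=O)[O-])cc2cnc(Nc3ccc4[nH]ccc4c3)nc21` gives 900 nM in this assay, the lowest of the three numbers. Compound 2 `Cn1c(=O)c(S(=O)(=O)c2ccccc2)cc2cnc(Nc3cnc4[nH]ccc4c3)nc21` gives 5000 nM in this assay, and compound 3 `O=c1c(S(=O)(=O)c2ccc(F)cc2F)cc2cnc(Nc3ccc4[nH]ccc4c3)nc2n1C1CCCCC1` gives 10000 nM in this assay. Both of these sit beyond the scatter from compound 1, so compound 1 is the strongest inhibitor of the three on the numbers shown. For the measured compounds named here, neither compound 2 nor compound 3 differs from compound 1 in one place only, so no single step is measured.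

Compound 4 `Cn1c(=O)c(S(=O)(=O)c2ccc(F)cc2)cc2cnc(Nc3ccc4[nH]ccc4c3)nc21` differs from compound 1 in one place: hydrogen in place of nitro on an aromatic carbon. The group that leaves is the nitro on an aromatic carbon of the six-membered aromatic ring of carbon only, ortho to a large group and meta to the fluoro group; a hydrogen enters in its place.

Going by the values given here, no measured pair shows what this change alone does. The expectation is a step from compound 1 to compound 4 toward a higher number, that is, a weaker inhibitor, of modest size, a 2.8-fold higher number from compound 1 to compound 4 (0.44 log units; beyond the scatter), with the possibility that it stays within the scatter. Compound 4 is therefore expected to give about 2500 nM in this assay, estimated to lie between 800 nM and 8000 nM.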

Compound 4, half-maximal inhibitory concentration: 200 nM
Compound 4: the middle estimate sits 13-fold (1.10 log units) above what was measured; measured number below the stated range.
By their numbers in this assay, from the lowest: compound 4; then compound 1; then compounds 2 and 3 (each within the scatter of the next).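

In this assay the nitro group of the 4-fluoro-2-nitrophenyl is not required for inhibition: going to the 4-fluorophenyl gives a stronger inhibitor (a 4.5-fold lower number from compound 1 to compound 4 (0.65 log units; beyond the scatter)). For the compounds shown here, this is the first single-place step, and it shows that this aromatic carbon, ortho to a large group and meta to a fluoro group, can lose 3 heavy atoms and 2 hydrogen-bond acceptors with a gain in inhibition, not a loss. Nothing at hand bears on the reason for this step.

Going by these compounds, whether hydrogen is the best choice at this aromatic carbon remains open: an amine or a methoxy group there would help show whether the loss of inhibition is tied to the nitro group or extends to other groups at this place. The fluoro group on the same ring also has no single-place comparison, so its contribution to the number of compound 4 in this assay cannot be read from the compounds shown.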